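A few compounds are considered here, and "the series" means these few. Any claim that something is new, unique, unknown or untested is made for them only; others in the source may bear on it.

Measured so far:
- compound 1, `COCC1CCN(c2c(S(=O)(=O)c3cc(F)cc(F)c3)cnc3cc(F)ccc23)CC1`, 83% in an assay on isolated protein for displacement of a labelled ligand from metabotropic glutamate receptor 5 (Homo sapiens), with a stated time of 60 min, tested at 1 uM; a higher number here means more inhibition at the concentration tested (going by the name of the read-out), a lower number less inhibition
- compound 2, `NC(=O)C1CCN(c2c(S(=O)(=O)c3ccccc3)cnc3ccccc23)CC1`, 24.8% in this assay

Compound 1 `COCC1CCN(c2c(S(=O)(=O)c3cc(F)cc(F)c3)cnc3cc(F)ccc23)CC1` and compound 2 `NC(=O)C1CCN(c2c(S(=O)(=O)c3ccccc3)cnc3ccccc23)CC1` share a core that carries a sulfonyl-linked phenyl ring and a saturated nitrogen ring on the aromatic core. In this assay compound 1 gives 83%, while compound 2 gives 24.8%. Compound 2 therefore stands lowest of the two numbers, and the gap to compound 1 is well beyond the usual scatter of this kind of measurement. The two compounds differ in several places at once, so no single cause for that gap can be read from them.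

Compound 3 `CCN1CCN(c2c(S(=O)(=O)c3ccccc3)cnc3ccccc23)CC1` is not yet measured. It differs from compound 2 in one place: 4-ethylpiperazin-1-yl in place of 4-carbamoylpiperidin-1-yl on an aromatic carbon. For the measured compounds named here, only one measured pair exists, and it does not isolate this change, so the direction of the step is uncertain. A moderate rise is expected, as the step of a number 20.2 percentage points higher from compound 2 to compound 3 (beyond the scatter) expresses. For compound 3 the value in this assay is estimated at 45%, within a range of 15% to 80%.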

Compound 3, a percentage reported as inhibition, at one concentration (the size of the read-out at that concentration, not a potency): 1.7%
Compound 3: the middle estimate sits 43.3 percentage points above what was measured; the whole stated range lies above it.
By their numbers in this assay, from the lowest: compound 3; then compound 2; then compound 1.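

Replacing 4-carbamoylpiperidin-1-yl with 4-ethylpiperazin-1-yl on the aromatic carbon ortho to a phenylsulfonyl group and opposite the ring nitrogen gives a number 23.1 percentage points lower from compound 2 to compound 3 (beyond the scatter) in this assay. For the compounds shown here, this is the first comparison in which everything else in the molecule stays the same, so it shows that the group at this position can by itself change the read-out by more than the usual scatter, and that this change lowers it. No supporting measurement is available to explain why the number falls.

The change replaces the ring and the group it carries in one move, so this pair cannot separate the effect of losing the carbamoyl group, gaining the ethyl group, or having a ring with a second hetero atom. Compounds carrying 4-ethylpiperidin-1-yl or 4-carbamoylpiperazin-1-yl at this position would each alter only part of the change, and 4-acetylpiperazin-1-yl would test a different group on the same ring as compound 3.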